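Carboxymethyl Amide Tested After a Weak Cyclopropyl Analogue

The source may hold more compounds than are shown below. What is called first, only, known or untested is meant among the compounds shown, and "the series" means these compounds.

Compound 1 `CCn1c(C(=O)NCCN)ccc1C(CC)(CC)c1ccc(OCS(=O)(=O)c2ccccc2)c(C)c1`: 6430 nM
Compound 2 `CCn1c(C(=O)NC2(CO)CC2)ccc1C(CC)(CC)c1ccc(OCS(=O)(=O)c2ccccc2)c(C)c1`: 45400 nM

In a functional assay on BXPC-3 cells (Homo sapiens) for antiproliferative activity, read by MTT assay, with a stated time of 24 h (a higher number here means a weaker inhibitor, a lower number a stronger inhibitor), compound 2 gives the higher of the two numbers shown. Going by the values given here, the only measured step, a 7.1-fold higher number from compound 1 to compound 2 (0.85 log units; beyond the scatter), concerns the group that now leaves and so bears only loosely on the next change. Compound 3 `CCn1c(C(=O)NCC(=O)O)ccc1C(CC)(CC)c1ccc(OCS(=O)(=O)c2ccccc2)c(C)c1` carries carboxymethyl in place of 1-(hydroxymethyl)cyclopropyl on an amide-type nitrogen. Among the compounds with values here, no measured step introduces carboxymethyl, so no direction beyond the scatter is expected. The step of a 1.5-fold lower number from compound 2 to compound 3 (0.18 log units; within the scatter) is therefore expected to stay small. Compound 3 is estimated at 30000 nM, with a range from 8000 nM to 110000 nM.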

Compound 3, half-maximal inhibitory concentration: > 50000 nM
Compound 3: no number, only a limit; the forecaster's own chance of this, stated with the estimate: 10%; middle value at least 1.6-fold (0.22 log units) from the limit.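

In this assay compound 3 reaches only a limit, not a number: the limit of > 50000 nM in this assay, at which 1 of the 3 values shown sits. Carboxy in place of aminomethyl on the chain gives an at least 7.7-fold higher number from compound 1 to compound 3 (0.89 log units; beyond the scatter), which shows that this position does not tolerate every small chain equally. Carboxymethyl in place of 1-(hydroxymethyl)cyclopropyl gives an at least 1.1-fold higher number from compound 2 to compound 3 (0.04 log units; that floor lies within the scatter), so the two amides cannot be placed in order.

The compounds shown leave open how far past its limit compound 3 lies. They also leave open whether a longer chain ending in an amine, or the methyl ester of the carboxylic acid, would read closer to compound 1.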